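This account rests on a few compounds, and the source may have more. Where it says the series, first, only, none or still open, it means among the compounds named here.

Three compounds share one core and differ only in the group attached to an aromatic carbon of a five-membered aromatic ring with three nitrogens. Compound 1 `CC(C)(C)c1cn(Cc2cc(=O)oc3cc(O)ccc23)nn1` carries a tert-butyl group, and in a functional assay on HeLa cells (Homo sapiens) for inhibition, read by MTT assay, with a stated time of 72 h (on this read-out lower numbers stand for stronger inhibition and higher numbers for weaker inhibition), compound 1 gives 81100 nM. Compound 2 `CCCCCCc1cn(Cc2cc(=O)oc3cc(O)ccc23)nn1` carries a hexyl chain; in this assay compound 2 gives 59000 nM. Compound 3 `CCCCCCCCc1cn(Cc2cc(=O)oc3cc(O)ccc23)nn1` carries an octyl chain; in this assay compound 3 gives 35100 nM, the lowest of the three numbers. The step of a 1.4-fold lower number from compound 1 to compound 2 (0.14 log units; within the scatter) and the step of a 1.7-fold lower number from compound 2 to compound 3 (0.23 log units; within the scatter) both stay within the scatter, while the step of a 2.3-fold lower number from compound 1 to compound 3 (0.36 log units; beyond the scatter) is modest but beyond it. Compound 4 `O=c1cc(Cn2cc(-c3ccc(Br)cc3)nn2)c2ccc(O)cc2o1` changes the same position again: 4-bromophenyl in place of octyl on an aromatic carbon. Within the data shown here, no measured step swaps a chain for an aromatic ring, so the three steps only show that tert-butyl gave a modestly higher number than octyl, and they give little guidance here. For compound 4 a small rise in the number, possibly within the scatter, is expected, a 1.6-fold higher number from compound 3 to compound 4 (0.20 log units; within the scatter). Compound 4 is therefore estimated at 55000 nM, with a range from 15000 nM to 200000 nM.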

Compound 4, half-maximal inhibitory concentration: 40200 nM
Compound 4: middle estimate off by 1.4-fold (0.14 log units), on the high side, within the range that was stated.
By their numbers in this assay, from the lowest: compounds 3, 4, 2 and 1 (each within the scatter of the next, the first and the last beyond it).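

Among these compounds, an aromatic ring can take the place of a saturated chain at this position, a swap the earlier compounds did not cover, and in this assay replacing octyl with 4-bromophenyl gives (a 1.1-fold higher number from compound 3 to compound 4 (0.06 log units; within the scatter)). Against the other two groups the picture is the same, with (a 1.5-fold lower number from compound 2 to compound 4 (0.17 log units; within the scatter)) for hexyl and (a 2.0-fold lower number from compound 1 to compound 4 (0.30 log units; within the scatter)) for tert-butyl, so 4-bromophenyl cannot be told apart from any of the three earlier groups on this read-out. No measurement on hand gives a reason for this result.

The compounds shown leave open what the bromine itself contributes, since a plain phenyl group does not appear among them. They also leave open whether a phenyl ring bearing an amine or a carboxylic acid, or a chain longer than octyl, would give a number clearly apart from these.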